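This account rests on a few compounds, and the source may have more. Where it says the series, first, only, none or still open, it means among the compounds named here.

Measured so far in an ADME assay on MT4 cells (Homo sapiens) for cytotoxicity, with a stated time of 5 days; a higher number here means that more compound is tolerated, a lower number that less compound is tolerated:
- compound 1 `CC(C)(C)C#Cc1cc(N(C(=O)[C@H]2CC[C@H](C)CC2)[C@H]2CC[C@H](Oc3ccc4nccn4n3)CC2)c(C(=O)O)s1` gives 133 nM
- compound 2 `CC(C)(C)C#Cc1cc(N(C(=O)[C@H]2CC[C@H](C)CC2)[C@H]2CC[C@](O)(CO[C@H]3CCOC3)CC2)c(C(=O)O)s1` gives 8980 nM
- compound 3 `CC1=CC[C@H](C(=O)N(c2cc(C#CC(C)(C)C)sc2C(=O)O)[C@H]2CC[C@](O)(CO[C@H]3CCOC3)CC2)CC1` gives 12100 nM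

Compound 1 stands lowest of the three, and compound 2 and compound 3 both lie higher, beyond the scatter. Compound 4 `CC(C)(C)C#Cc1cc(N(C(=O)[C@H]2CC[C@H](C)CC2)[C@H]2CC[C@H](Oc3ccccn3)CC2)c(C(=O)O)s1` departs from compound 1 as follows: a group of 6 heavy atoms (5 carbon, 1 nitrogen; one six-membered aromatic ring with 1 hetero atom) in place of a group of 9 heavy atoms (6 carbon, 3 nitrogen; one five-membered aromatic ring with 2 hetero atoms, one six-membered aromatic ring with 2 hetero atoms), on an oxygen on a saturated carbon with pyridin-2-yl as the entering group. For the measured compounds named here, the only measured step (a 1.3-fold higher number from compound 2 to compound 3 (0.13 log units; within the scatter)) lies within the scatter and sits elsewhere, on a carbonyl carbon, so it gives no direct size for this change. An upward move is expected, on weak grounds, since compound 1 at 133 nM lies far under compound 2 at 8980 nM in this assay and the two differ in this same region. The expected step is an 11-fold higher number from compound 1 to compound 4 (1.05 log units; beyond the scatter) with wide uncertainty. Compound 4 is estimated at 1500 nM (range 250 nM to 10000 nM).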

Compound 4, half-maximal cytotoxic concentration: 100 nM
Beside the measured number, compound 4's estimate is 15-fold (1.18 log units) above it, outside the stated range (below it).
By their numbers in this assay, from the lowest: compounds 4 and 1 (each within the scatter of the next); then compounds 2 and 3 (each within the scatter of the next).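

In this assay, pyridin-2-yl in place of the larger group of 9 heavy atoms, on an oxygen on a saturated carbon, gives a 1.3-fold lower number from compound 1 to compound 4 (0.12 log units; within the scatter). Dropping the five-membered aromatic ring therefore leaves this read-out unchanged within the scatter, so that ring is not needed for the number seen with compound 1. Both aromatic groups on this oxygen give closely similar numbers.

Open, as far as these compounds go, is whether a phenyl or a plain methyl on this oxygen would give a similar number. Nothing at hand bears on the cause of this result.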